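A hydroxy for amino swap at the assay limit

A few compounds are considered here, and "the series" means these few. Any claim that something is new, unique, unknown or untested is made for them only; others in the source may bear on it.

Of the compounds shown here, three have been measured in an ADME assay on L1210/0 cells (Mus musculus) for cytotoxicity, with a stated time of 48 h; a higher number here means a weaker inhibitor, a lower number a stronger inhibitor. Compound 1 `CC1=C(C)C(=O)C(c2cn([C@H]3C[C@H](O)[C@@H](CO)O3)c(=O)[nH]c2=O)=C(C)C1=O` gives 174000 nM. Compound 2 `Nc1ncnc2c1ncn2C[C@@H]1CCC[C@H]1CO` gives > 200000 nM, which is a limit and not a number. Compound 3 `C[C@@]1(CO)O[C@H](c2cc(F)c(N)cc2F)C[C@@H]1O` gives > 200000 nM, which is also a limit. Going by these compounds, compound 2 therefore stands at the limit of > 200000 nM in this assay, at which 2 of the 3 values shown sit, and its true value in this assay remains unknown.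

Compound 4 `OC[C@@H]1CCC[C@H]1Cn1cnc2c(O)ncnc21` differs from compound 2 at a single place: hydroxy in place of amino on an aromatic carbon. This is hydroxy in place of amino on an aromatic carbon. Among the compounds with values here, no measured pair of compounds shows this change, so the data give no direct guide to its size. The expectation rests on compound 2, which gives > 200000 nM, a limit once more. No step beyond the usual scatter is expected, and so no clear direction either. The estimate is a step that the limit leaves unreadable from compound 2 to compound 4, a step expected to stay within the scatter. Compound 4 is estimated at 220000 nM, with an expected range of 100000 nM to 450000 nM.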

Compound 4, half-maximal inhibitory concentration: > 200000 nM
Compound 4: no number, only a limit (the forecaster's own chance of this, stated with the estimate: 80%); the middle value lies beyond the limit too.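

No step can be read between compound 2 and compound 4, because both values are limits and not numbers: the limit of > 200000 nM in this assay, at which 3 of the 4 values shown sit.

The compounds shown leave open whether hydroxy in place of amino on an aromatic carbon shifts the true half-maximal inhibitory concentration at all, and in which direction.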